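Ethylsulfonyl in Place of (2-Fluorophenyl)sulfonyl

A few compounds are considered here, and "the series" means these few. Any claim that something is new, unique, unknown or untested is made for them only; others in the source may bear on it.

Of the compounds shown here, three built on one shared core have been measured in a functional assay on CHO.K1 cells for antagonist activity at prostaglandin D2 receptor 2 (Homo sapiens), read by GTPgammaS binding, with a stated time of 1 h; a higher number here means a weaker inhibitor, a lower number a stronger inhibitor. Compound 1 `COC(=O)c1ccc(Cc2c3c(n(CC(=O)O)c2C)CCNC3=O)c(S(=O)(=O)c2ccccc2)c1` gives 11 nM. Compound 2 `Cc1c(Cc2cc(F)ccc2S(=O)(=O)c2ccccc2)c2c(n1CC(=O)O)CCNC2=O` gives 3.7 nM, and compound 3 `Cc1c(Cc2ccccc2S(=O)(=O)c2ccccc2F)c2c(n1CC(=O)O)CCNC2=O` gives 3.6 nM. The numbers for compound 2 and compound 3 lie within the usual scatter of each other, so no order between them can be read, while the number for compound 1 sits beyond the scatter, higher than both.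

Compound 4 `CCS(=O)(=O)c1ccccc1Cc1c2c(n(CC(=O)O)c1C)CCNC2=O` differs from compound 3 in one place: ethyl in place of 2-fluorophenyl on a sulfonyl sulfur. Within the data shown here, no measured pair in this set shows the effect of such a change, so nothing here tells its size directly. The part that leaves carries one six-membered aromatic ring of carbon only, the part that enters carries no ring, and every measured compound keeps such a ring on the sulfonyl sulfur. The expected step is an 11-fold higher number from compound 3 to compound 4 (1.05 log units; beyond the scatter), a rise in the number beyond the scatter. Compound 4 is estimated to give 40 nM in this assay, with a range from 8 nM to 250 nM.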

Compound 4, half-maximal inhibitory concentration: 550 nM
Beside the measured number, compound 4's estimate is 14-fold (1.14 log units) below it; the measured number lies above the stated range.
By their numbers in this assay, from the lowest: compounds 3 and 2 (each within the scatter of the next); then compound 1; then compound 4.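

Putting ethyl in place of 2-fluorophenyl on the sulfonyl sulfur gives a 150-fold higher number from compound 3 to compound 4 (2.18 log units; beyond the scatter) in this assay, so what sits on this sulfur can change the number greatly. Among these compounds, the earlier compounds could not show this, since all of them keep a six-membered aromatic ring of carbon there and differ elsewhere; compound 4 is the only one with no ring on this sulfur, and its number is the highest of the four. Nothing measured here gives a reason for so large a rise.

A single pair also cannot separate the loss of the ring from the loss of the fluorine or from the drop in heavy atoms. Going by these compounds, it remains open whether a longer chain such as butyl, a saturated ring such as cyclohexyl, or a pyridine ring on this sulfur would keep the number low or raise it as ethyl does.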